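A few compounds are considered here, and "the series" means these few. Any claim that something is new, unique, unknown or untested is made for them only; others in the source may bear on it.

Of the compounds shown here, three built on a shared core have been tested in a functional assay on HEK293 cells for activation of melanin-concentrating hormone receptor 1 (Rattus norvegicus), read by inositol phosphate accumulation; a higher number here means that more compound is needed for the effect, a lower number that less compound is needed. Compound 1 `CC1CCCN1c1ccc2cc(NC(=O)CCc3ccc(C(F)(F)F)cc3)ccc2n1` gives 270 nM. Compound 2 `CC(C)C(=O)NC1CCN(c2ccc3cc(NC(=O)CCc4ccc(C(F)(F)F)cc4)ccc3n2)C1` gives 90 nM, and compound 3 `O=C(CCCCCCCCCCCCc1ccc(C(F)(F)F)cc1)Nc1ccc2nc([N+]34CCC(CC3)CC4)ccc2c1` gives 25 nM. Going by the values given here, compound 2 therefore stands second highest of the three numbers: the only single-change step among them, a 3.0-fold lower number from compound 1 to compound 2 (0.48 log units; beyond the scatter), separates it from compound 1, while compound 3 sits at a lower number still, with no one-place comparison to compound 2 available.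

The next compound, compound 4 `NC1CCN(c2ccc3cc(NC(=O)CCc4ccc(C(F)(F)F)cc4)ccc3n2)C1`, differs from compound 2 in one place: hydrogen in place of isopropylcarbonyl on an amine nitrogen. Put more broadly, the (isopropylcarbonyl)amino group becomes a plain amino group.

Among the compounds with values here, only one measured step touches this part of the molecule, a 3.0-fold lower number from compound 1 to compound 2 (0.48 log units; beyond the scatter), and it concerns exchanging the whole ring substituent rather than trimming the group on the amine nitrogen; no measured pair sets an acylated amine against a free one. The guide is therefore weak. The expectation is that removing the isopropylcarbonyl brings no change beyond the scatter, so the step in this assay is estimated at about a 1.1-fold higher number from compound 2 to compound 4 (0.05 log units; within the scatter). Compound 4 is accordingly estimated at 100 nM, with a range from 30 nM to 350 nM.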

Compound 4, half-maximal effective concentration: 200 nM
The estimate for compound 4 lay 2.0-fold (0.30 log units) below the measured number; the measured number falls inside the stated range.
By their numbers in this assay, from the lowest: compound 3; then compound 2; then compounds 4 and 1 (each within the scatter of the next).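

Until now this position had been seen only through an exchange of the whole ring substituent, but here the group on the amine nitrogen changes alone, and in this assay removing the isopropylcarbonyl gives a 2.2-fold higher number from compound 2 to compound 4 (0.35 log units; beyond the scatter) as a modest step. The plain 3-aminopyrrolidin-1-yl group, set against the 2-methylpyrrolidin-1-yl group, gives a 1.4-fold lower number from compound 1 to compound 4 (0.13 log units; within the scatter) and so does not separate these two compounds; the difference between compound 1 and compound 2 therefore appears only with the isopropylcarbonyl in place on the amine nitrogen. Nothing measured here offers a reason for this result.

The compounds shown leave open whether the whole isopropylcarbonyl matters or only part of it; an acetyl group, a longer acyl chain or a methanesulfonyl group on the same nitrogen would help tell these readings apart. They also leave open whether the same step would hold alongside the long chain of compound 3, which differs from compound 2 in more than one place.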